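A few compounds are considered here, and "the series" means these few. Any claim that something is new, unique, unknown or untested is made for them only; others in the source may bear on it.

Four compounds are compared here, each built on a fused two-ring core that carries a methyl group and a benzyl group. Compound 1 `COc1ccc2c(=O)c(Cc3ccccc3)c(C)[nH]c2c1` and compound 3 `COc1ccc2nc(C)c(Cc3ccccc3)c(OC)c2c1` differ in their cores; the difference between the two cores is not broken down here. In a physicochemical assay for solubility, read by HPLC, at pH 7.4 (on this read-out higher numbers stand for higher solubility and lower numbers for lower solubility), compound 1 gives 5000 nM. In this assay compound 3 gives 2000 nM, a lower number than compound 1.

Compound 2 `Cc1[nH]c2cc(Cl)ccc2c(=O)c1Cc1ccccc1` differs from compound 1 by chloro in place of methoxy on an aromatic carbon. In this assay compound 2 returns only a limit of the assay, < 2000 nM, not a number. The step of an at least 2.5-fold lower number from compound 1 to compound 2 (0.39 log units; beyond the scatter) is therefore open at its far end, because it meets (the limit of < 2000 nM in this assay, at which 1 of the 3 values shown sits).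

Compound 4 `COc1c(Cc2ccccc2)c(C)nc2ccc(Cl)cc12` is not yet measured. It differs from compound 3 by chloro in place of methoxy on an aromatic carbon, the same change as from compound 1 to compound 2, at a place described in the same words. A step of similar size is expected, resting on an at least 2.5-fold lower number from compound 1 to compound 2 (0.39 log units; beyond the scatter), which would carry compound 4 beneath the reporting floor. The value expected for compound 4 in this assay is 800 nM, a step of a 2.5-fold lower number from compound 3 to compound 4 (0.40 log units; beyond the scatter), with a real chance that only a limit is returned.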

Compound 4, solubility: < 2000 nM
Compound 4: only a limit was reported (the forecaster's own chance of this, stated with the estimate: 75%); the middle value lies beyond the limit too.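

On the core of compound 3, chloro in place of methoxy on an aromatic carbon gives a number no higher from compound 3 to compound 4 (the limit leaves the size open) in this assay, which agrees in direction with an at least 2.5-fold lower number from compound 1 to compound 2 (0.39 log units; beyond the scatter). Compound 4 returns only a limit of the assay, < 2000 nM, not a number. The change therefore points the same way on both cores, but its size on the second core cannot be read, and nothing shows that the two steps match, since each of them ends at a limit: the limit of < 2000 nM in this assay, at which 2 of the 4 values shown sit.

The compounds shown leave open how far the number really falls with this change, and whether the same direction would hold on any further core. They also leave open what a different group on this aromatic carbon would do, such as an amine, a carboxylic acid or a longer chain in place of methoxy, and whether any of these would give a readable number.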